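Second Bromine on the Hydroxybenzyl Ring

The compounds below may be only part of what the source reports. "The series", "measured", "known", "first", "only" and "open" are said of these compounds alone.

compound 1 `COC(=O)/C=C/c1ccc(NCc2ccccc2O)cc1` — 31700 nM
compound 2 `COC(=O)/C=C/c1ccc(NCc2cc(Br)ccc2O)cc1` — 109000 nM

In a functional assay on MDA-MB-231 cells (Homo sapiens) for antiproliferative activity, read by WST assay, with a stated time of 72 h (on this read-out lower numbers stand for stronger inhibition and higher numbers for weaker inhibition), compound 1 gives 31700 nM, and compound 2 gives 109000 nM. Compound 2 therefore stands highest of the two numbers shown; its nearest neighbour is compound 1, and the step of a 3.4-fold higher number from compound 1 to compound 2 (0.54 log units; beyond the scatter) lies beyond the scatter, so compound 2 is the weaker inhibitor of the pair.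

Compound 3 `COC(=O)/C=C/c1ccc(NCc2cc(Br)cc(Br)c2O)cc1` differs from compound 2 by bromo in place of hydrogen on an aromatic carbon. Going by the values given here, the only measured step that bears on this change is a 3.4-fold higher number from compound 1 to compound 2 (0.54 log units; beyond the scatter), in which the first bromo entering the same ring raised the number by a modest amount beyond the scatter. Among the compounds with values here, no measured pair shows what a second bromo on this ring does, so the expectation rests on that single step alone. Compound 3 is expected to move by a 1.7-fold higher number from compound 2 to compound 3 (0.22 log units; within the scatter), a step of similar kind toward weaker inhibition, with wide uncertainty, and with a real chance that so high a number is reported only as a limit of this assay. Compound 3 is thus estimated at 180000 nM, within a range from 60000 nM to 500000 nM.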

Compound 3, half-maximal inhibitory concentration: 11500 nM
Estimate against measurement, compound 3: 16-fold (1.19 log units) above; the measured number lies below the stated range.
By their numbers in this assay, from the lowest: compound 3; then compound 1; then compound 2.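

In this assay, the second bromo runs opposite to the first, with a 9.5-fold lower number from compound 2 to compound 3 (0.98 log units; beyond the scatter), whereas the earlier replacement on this ring gave a 3.4-fold higher number from compound 1 to compound 2 (0.54 log units; beyond the scatter). The same change, bromo in place of hydrogen on an aromatic carbon, thus carries no single direction on this ring: at this place, ortho to a hydroxy group and meta to a bromo group, it goes with stronger inhibition, so the earlier step cannot be carried over to it. No measurement shown here speaks to what lies behind this reversal.

The compounds shown leave open whether the lower number needs the bromo already on the ring, since the effect of a bromo at this place without that first bromo cannot be read from them. On these data alone, it also remains open whether a chlorine, a methyl group or a methoxy group at this same place would go with stronger inhibition too, or whether the change is particular to bromo.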